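This account rests on a few compounds, and the source may have more. Where it says the series, first, only, none or still open, it means among the compounds named here.

In a functional assay on HeLa cells (Homo sapiens) for antiproliferative activity, read by sulforhodamine B assay, with a stated time of 72 h (a lower number here means a stronger inhibitor, a higher number a weaker inhibitor), three thiosemicarbazones have been examined. Compound 1 `CN(C)C(=S)N/N=C/c1ccc2cccnc2n1` gives 970 nM, and compound 3 `CN(C)C(=S)N/N=C/c1cnc2ccccc2n1` gives 750 nM. Compound 2 `S=C(NCc1ccccc1)N/N=C/c1ccc2ccccc2n1` gives 62800 nM, which is the highest of the three numbers: it stands far above compound 1 and further still above compound 3, both gaps lying well beyond the scatter of the measurement. Compound 2 is thus the weakest inhibitor of the three, whereas compound 1 and compound 3 lie within the scatter of each other.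

Compound 4 `Fc1cccc(NC(=S)N/N=C/c2ccc3ccccc3n2)c1` has not yet been measured. It is compound 2 with one change: 3-fluorophenyl in place of benzyl on an amide-type nitrogen. For the measured compounds named here, nothing measured here speaks directly to this change, since no pair of measured compounds differs in this way, and the two potent compounds carry a dimethyl group at that nitrogen rather than any aryl or benzyl group. The account therefore expects, with considerable uncertainty, a moderate step in this assay from compound 2 to compound 4 toward a lower number, of the size a 4.2-fold lower number from compound 2 to compound 4 (0.62 log units; beyond the scatter). On that basis compound 4 is estimated to give about 15000 nM in this assay, within a range from 2000 nM to 100000 nM.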

Compound 4, half-maximal inhibitory concentration: 70100 nM
The estimate for compound 4 lay 4.7-fold (0.67 log units) below the measured number; measured number inside the range.
By their numbers in this assay, from the lowest: compounds 3 and 1 (each within the scatter of the next); then compounds 2 and 4 (each within the scatter of the next).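

In this assay, 3-fluorophenyl in place of benzyl on an amide-type nitrogen gives a 1.1-fold higher number from compound 2 to compound 4 (0.05 log units; within the scatter), so the two groups cannot be told apart in this assay. For the compounds shown here, no earlier pair differed at this nitrogen alone; this step is the first direct reading of the position, and it shows that on the core of compound 2 this exchange of one group with a six-membered aromatic ring of carbon only for another leaves the number within the scatter. Nothing available explains why the exchange leaves the number within the scatter.

From the compounds shown here alone, compound 1 and compound 3 differ from compound 2 and compound 4 in more than one place, so it remains open whether the dimethyl group on the core of compound 2 would give a different number, or whether a smaller or non-aromatic group there, such as an ethyl chain or a morpholine ring, would do so. Also open, going by these compounds, is how a plain phenyl group, or a fluorine placed elsewhere on the ring, would read at this nitrogen.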